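Adding iodo to the phenyl ring of compound 1

The source may hold more compounds than are shown below. What is called first, only, known or untested is meant among the compounds shown, and "the series" means these compounds.

In a functional assay (strain AB) with Danio rerio as the target, read by microscopy, with a stated time of 1 h (on this read-out higher numbers stand for an effect only at larger amounts of compound and lower numbers for an effect already at smaller amounts), compound 1 `CCN1CCc2c(sc(NC(=O)Nc3ccccc3)c2C(N)=O)C1` gives > 25000 nM, which is a limit and not a number. Compound 2 `CC(C)(C)OC(=O)N1CCc2c(sc(NC(=O)Nc3ccc(Cl)cc3)c2C(N)=O)C1` gives > 25000 nM, which is also a limit. Compound 3 `CC(C)N1CCc2c(sc(NC(=O)Nc3ccc(Cl)cc3)c2C(N)=O)C1` gives a true number, 1490 nM. Compound 1 therefore stands at the limit of > 25000 nM in this assay, at which 2 of the 3 values shown sit.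

Compound 4 `CCN1CCc2c(sc(NC(=O)Nc3ccc(I)cc3)c2C(N)=O)C1` carries iodo in place of hydrogen on an aromatic carbon, para to a large group: iodo in place of hydrogen on an aromatic carbon. Among the measured compounds shown here, no measured step changes that aromatic ring alone. For the measured compounds named here, the one measured step, an at least 16-fold lower number from compound 2 to compound 3 (1.22 log units; beyond the scatter), changes the group on the ring nitrogen, so it bears on this change only indirectly. It does show that compound 3 has a chloro on its phenyl ring and a small alkyl group on that nitrogen, and compound 4 is expected to give a true number as well because compound 3 gives 1490 nM. A large step toward a lower number is therefore expected, estimated as an at least 10-fold lower number from compound 1 to compound 4 (1.00 log units; beyond the scatter). For compound 4 the expected value is 2500 nM, with an estimated range of 600 nM to 12000 nM.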

Compound 4, half-maximal effective concentration: 1620 nM
Compound 4: middle estimate off by 1.5-fold (0.19 log units), on the high side; the measured number falls inside the stated range.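

Iodo in place of hydrogen on an aromatic carbon, para to a large group, gives an at least 15-fold lower number from compound 1 to compound 4 (1.18 log units; beyond the scatter) in this assay, and this single heavy atom takes the compound from a limit to a true number. The earlier step concerned only the group on the ring nitrogen, whereas this one shows that the phenyl ring also counts while that nitrogen group stays unchanged. Compound 1 gives a limit and not a number, so the full size of this step stays unknown: the limit of > 25000 nM in this assay, at which 2 of the 4 values shown sit.

The compounds shown leave open whether iodo is special at this place or whether bromo, methyl or methoxy on the same core would give a similar step. They also do not tell whether an amine or a carboxylic acid would be tolerated there, or how iodo behaves with a longer chain on the ring nitrogen.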